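Removing a ring methyl from two related aza-bicyclic cores

A few compounds are considered here, and "the series" means these few. Any claim that something is new, unique, unknown or untested is made for them only; others in the source may bear on it.

Measured so far, in a functional assay on OVCAR-3 cells (Homo sapiens); on this read-out higher numbers stand for weaker inhibition of growth and lower numbers for stronger inhibition of growth:
compound 1 `Oc1cc(-c2ccc(Cl)cc2)nc2ncccc12` gives 23400 nM
compound 2 `COc1ccc(-c2cc(O)c3c(C)cc(C)nc3n2)cc1` gives 32400 nM
compound 3 `Cc1cnc2nc(-c3ccc(Cl)cc3)cc(O)c2c1` gives 2240 nM

Compound 3 and compound 1 differ in one place: hydrogen in place of methyl on an aromatic carbon. That change produced a 10-fold higher number from compound 3 to compound 1 (1.02 log units; beyond the scatter). Compound 2 and compound 3 have different cores; the difference between the two cores is not broken down here.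

The unmeasured compound 4 `COc1ccc(-c2cc(O)c3ccc(C)nc3n2)cc1` comes from compound 2 by the same kind of change, (hydrogen in place of methyl on an aromatic carbon). The surroundings are not identical: in compound 3 the methyl stands two atoms from the ring nitrogen, meta and para to a fused ring, whereas in compound 2 it stands ortho and meta to a fused ring, meta to a methyl group and opposite the ring nitrogen.

Because compound 3 to compound 1 gave a 10-fold higher number from compound 3 to compound 1 (1.02 log units; beyond the scatter), a step in the same direction, though smaller, is expected for compound 4: a 2.2-fold higher number from compound 2 to compound 4 (0.33 log units; beyond the scatter). Compound 4 is estimated at 70000 nM, between 25000 nM and 250000 nM.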

Compound 4, concentration for 50% growth inhibition: > 100000 nM
Compound 4 gave a limit, no number (the forecaster's own chance of this, stated with the estimate: 25%); middle value at least 1.4-fold (0.15 log units) from the limit.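

In this assay, replacing the methyl with hydrogen on the core of compound 2 gave an at least 3.0-fold higher number from compound 2 to compound 4 (0.48 log units; beyond the scatter), so the change moved the number in the same direction on both cores shown. Compound 4 gave a limit of the assay rather than a number: the limit of > 100000 nM in this assay, at which 1 of the 4 values shown sits. This shows that the direction carried over in these two pairs, but it does not show that the size of the step carried over: the same change on two cores in this assay, a 10-fold higher number (1.02 log units; beyond the scatter) from compound 3 to compound 1 and an at least 3.0-fold higher number (0.48 log units; beyond the scatter) from compound 2 to compound 4; the limit leaves it open whether they differ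

The compounds shown leave open how the read-out would respond to a group other than methyl or hydrogen at this place. An ethyl group, an amine or a carboxylic acid there could give a different result on either core.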